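The source may hold more compounds than are shown below. What is called first, only, known or untested is meant among the compounds shown, and "the series" means these compounds.

Series so far, in a functional assay on OVCAR cells (Homo sapiens) for cytotoxicity, read by sulforhodamine B assay, with a stated time of 48 h; on this read-out lower numbers stand for stronger inhibition and higher numbers for weaker inhibition:
- compound 1 `CC(=O)N1N=C(c2ccccc2)CC1c1cccc(Cl)c1Cl`: 36800 nM
- compound 2 `CC(=O)N1N=C(c2ccco2)CC1c1ccc([N+](=O)[O-])cc1`: 23000 nM

Compound 2 and compound 1 lie within the scatter of each other, so the two numbers do not separate them. Compound 3 `CC(=O)N1N=C(c2ccco2)CC1c1ccc(N(C)C)cc1` differs from compound 2 in one place, with dimethylamino in place of nitro on an aromatic carbon, para to a large group (dimethylamino in place of nitro on an aromatic carbon). For the measured compounds named here, no measured pair shows this exchange, so the expectation has little support. No step beyond the scatter is expected, and neither direction is favoured. The estimated change is a 1.2-fold lower number from compound 2 to compound 3 (0.06 log units; within the scatter). For compound 3 the expected value is 20000 nM, with an estimated range of 7000 nM to 50000 nM.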

Compound 3, half-maximal inhibitory concentration: 14600 nM
Compound 3: middle estimate off by 1.4-fold (0.14 log units), on the high side; the measured number falls inside the stated range.
By their numbers in this assay, from the lowest: compounds 3, 2 and 1 (each within the scatter of the next, the first and the last beyond it).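

At this position, an aromatic carbon para to a large group, the series now has its first single-place comparison. In this assay, dimethylamino in place of nitro gives a 1.6-fold lower number from compound 2 to compound 3 (0.20 log units; within the scatter) and so does not separate the two groups, although they differ in their atoms and in their hydrogen-bond acceptors. No measurement at hand accounts for this result.

From the compounds shown here alone, whether a primary amine, a carboxylic acid or a longer chain at this position would give a step beyond the scatter remains open. Going by these compounds, whether the same exchange would read alike on the core of compound 1 also remains open.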